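The source may hold more compounds than are shown below. What is called first, only, known or untested is meant among the compounds shown, and "the series" means these compounds.

The set rests on one shared core, and the differences lie on an outer ring. Within the data shown here, compound 1 `O=C(Nc1cccc(-c2ccccc2C(F)(F)F)c1)C(Cl)Cl` is the only member for which a number exists: in a functional assay on NCI-H460 cells (Homo sapiens) for cytotoxicity, read by MTT assay, with a stated time of 68 h (on this read-out higher numbers stand for weaker inhibition and lower numbers for stronger inhibition), compound 1 gives 7550 nM. Compound 2 `O=C(Nc1cccc(-c2ccc(F)cc2)c1)C(Cl)Cl` in this assay gives > 50000 nM, which is a limit of the assay and not a number. Compound 3 `COC(=O)c1ccc(-c2cccc(NC(=O)C(Cl)Cl)c2)cc1` in this assay gives > 50000 nM, again a limit rather than a number. Among the measured compounds shown here, the single step between measured compounds, a step that the two limits leave unreadable from compound 2 to compound 3, runs from one limit to another, so its size cannot be read; the limit of > 50000 nM in this assay, at which 2 of the 3 values shown sit, describes where both of those values sit.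

Compound 4 `O=C(Nc1cccc(-c2ccccc2)c1)C(Cl)Cl` differs from compound 1 by hydrogen in place of trifluoromethyl on an aromatic carbon. For the measured compounds named here, no measured step reports a change at this position, so nothing here gives its size directly. Going by the values given here, what the data do show is that compound 1, the one with a trifluoromethyl group, is the one with a number, while the limit of > 50000 nM in this assay, at which 2 of the 3 values shown sit, holds both compounds that lack it. On that ground compound 4 is expected to be weaker than compound 1, by an estimated 3.3-fold higher number from compound 1 to compound 4 (0.52 log units; beyond the scatter). Compound 4 is estimated at 25000 nM, with a range from 6000 nM to 60000 nM, and it may well return only a limit.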

Compound 4, half-maximal inhibitory concentration: 20200 nM
The estimate for compound 4 lay 1.2-fold (0.09 log units) above the measured number, within the range that was stated.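

In this assay, compound 4 gives this position its first readable step, and taking trifluoromethyl away for hydrogen weakens the compound by a modest amount: a 2.7-fold higher number from compound 1 to compound 4 (0.43 log units; beyond the scatter). The compound carrying hydrogen also stands apart from the two fluoro and methoxycarbonyl compounds, with an at least 2.4-fold lower number from compound 3 to compound 4 (0.39 log units; beyond the scatter) and an at least 2.4-fold lower number from compound 2 to compound 4 (0.39 log units; beyond the scatter), so of these three groups only trifluoromethyl goes with a lower number than hydrogen. Compound 2 and compound 3 each remain at a limit of the assay rather than a number, so the step between them cannot be read: the limit of > 50000 nM in this assay, at which 2 of the 4 values shown sit.

Going by these compounds, what a methyl group, a chlorine atom or an amine would do on that same aromatic carbon stays open. On these data alone, how far compound 2 and compound 3 truly lie from compound 4 also stays open.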